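A few compounds are considered here, and "the series" means these few. Any claim that something is new, unique, unknown or untested is made for them only; others in the source may bear on it.

Measured so far:
- compound 1 `C[C@@]1(O)[C@H](O)[C@@H](CO)O[C@H]1n1cnc2c(N)nc(N=[N+]=[N-])nc21`: in an ADME assay on CCRF-CEM cells (Homo sapiens) for cytotoxicity, read by trypan blue exclusion, with a stated time of 6 days (on this read-out higher numbers stand for lower toxicity in this test and lower numbers for higher toxicity in this test), compound 1 gives > 100000 nM, a limit of the assay, not a number.
- compound 2 `COc1nc(N)c2ncn([C@@H]3O[C@H](CO)[C@@H](O)[C@@]3(C)O)c2n1`: in this assay compound 2 gives > 100000 nM, likewise a limit.

Going by the values given here, compound 2 therefore stands only at the limit, as does the one other value; both sit at the limit of > 100000 nM in this assay, at which 2 of the 2 values shown sit. Among the compounds with values here, the single measured step, a step that the two limits leave unreadable from compound 1 to compound 2, is unreadable, since both ends are limits. Compound 3 `C[C@@]1(O)[C@H](O)[C@@H](CO)O[C@H]1n1cnc2c(N)nc(F)nc21` differs from compound 2 by fluoro in place of methoxy on an aromatic carbon, on the aromatic carbon between two ring nitrogen atoms. The measured step gives no readable size, so no step beyond the scatter can be expected; compound 3 is estimated to remain at the limit, as 100000 nM (30000 nM to 300000 nM). The step from compound 2 to compound 3 is thus expected to be a number no higher from compound 2 to compound 3 (the limit leaves the size open).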

Compound 3, half-maximal cytotoxic concentration: > 100000 nM
Compound 3 ended at the assay's limit (the forecaster's own chance of this, stated with the estimate: 85%); the middle value sits exactly at the limit.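

No step can be read among compound 1, compound 2 and compound 3, as each value is a limit: the limit of > 100000 nM in this assay, at which 3 of the 3 values shown sit. Going by these compounds, how the azido, methoxy and fluoro compounds rank in this assay remains open.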